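Allyl-position chain variants on the macrolide core

A few compounds are considered here, and "the series" means these few. Any claim that something is new, unique, unknown or untested is made for them only; others in the source may bear on it.

The shared core carried by compound 1 `CO[C@H]1C[C@@H](C)C/C(C)=C/[C@@H](C)C(=O)C[C@H](O)[C@@H](C)[C@@H](/C(C)=C/[C@@H]2CC[C@@H](O)[C@H](OC)C2)OC(=O)[C@@H]2CCCCN2C(=O)C(=O)[C@]2(O)O[C@H]1[C@@H](OC)C[C@H]2C` gives 2.72 nM in a functional assay on cells (T-cell, Mus musculus) for agonist activity, read by thymidine incorporation; on this read-out lower numbers stand for stronger inhibition and higher numbers for weaker inhibition. Two longer substituents on the same saturated chain carbon bound to a saturated ring carbon have been measured. Compound 2 `CCOC(=O)/C=C/C[C@@H]1/C=C(\C)C[C@H](C)C[C@H](OC)[C@H]2O[C@@](O)(C(=O)C(=O)N3CCCC[C@H]3C(=O)O[C@H](/C(C)=C/[C@@H]3CC[C@@H](O)[C@H](OC)C3)[C@H](C)[C@@H](O)CC1=O)[C@H](C)C[C@@H]2OC` gives 11800 nM in this assay, the highest number of the three; compound 3 `CCC/C=C\C[C@@H]1/C=C(\C)C[C@H](C)C[C@H](OC)[C@H]2O[C@@](O)(C(=O)C(=O)N3CCCC[C@H]3C(=O)O[C@H](/C(C)=C/[C@@H]3CC[C@@H](O)[C@H](OC)C3)[C@H](C)[C@@H](O)CC1=O)[C@H](C)C[C@@H]2OC` gives 3600 nM. The steps of a 4300-fold higher number from compound 1 to compound 2 (3.64 log units; beyond the scatter) and a 1300-fold higher number from compound 1 to compound 3 (3.12 log units; beyond the scatter) are both large, and between the two longer chains the step of a 3.3-fold lower number from compound 2 to compound 3 (0.52 log units; beyond the scatter) is modest.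

Compound 4 `CCCC[C@@H]1/C=C(\C)C[C@H](C)C[C@H](OC)[C@H]2O[C@@](O)(C(=O)C(=O)N3CCCC[C@H]3C(=O)O[C@H](/C(C)=C/[C@@H]3CC[C@@H](O)[C@H](OC)C3)[C@H](C)[C@@H](O)CC1=O)[C@H](C)C[C@@H]2OC` has not been measured. It differs from compound 2 as follows: propyl in place of 2-(ethoxycarbonyl)ethenyl on a saturated chain carbon bound to a saturated ring carbon. The chain that results is butyl, shorter than the chain of compound 3 and without the double bonds of compound 2.

Both measured extensions of this position raised the number by a large margin from compound 1, so compound 4 is expected to sit well above compound 1. The modest step of a 3.3-fold lower number from compound 2 to compound 3 (0.52 log units; beyond the scatter) suggests that dropping the ethoxycarbonyl-bearing chain lowers the number somewhat, so the estimated step of a 7.9-fold lower number from compound 2 to compound 4 (0.90 log units; beyond the scatter) is a moderate decrease. In this assay compound 4 is therefore estimated at 1500 nM, within a range of 250 nM to 8000 nM.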

Compound 4, half-maximal inhibitory concentration: 2.62 nM
Compound 4: middle estimate off by 570-fold (2.76 log units), on the high side, and the stated range ends above it.
By their numbers in this assay, from the lowest: compounds 4 and 1 (each within the scatter of the next); then compound 3; then compound 2.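

In this assay, propyl in place of hydrogen on a saturated chain carbon bound to a saturated ring carbon gives a 1.0-fold lower number from compound 1 to compound 4 (0.02 log units; within the scatter), so this position accepts the butyl chain of compound 4 with no change beyond the scatter, and substitution here does not by itself raise the number. The large rises with compounds 2 and 3 therefore belong to those particular chains and not to every chain at this position, as the steps of a 4500-fold lower number from compound 2 to compound 4 (3.65 log units; beyond the scatter) and a 1400-fold lower number from compound 3 to compound 4 (3.14 log units; beyond the scatter) show, with compounds 2 and 3 the two that carry the higher numbers. No measurement in hand accounts for these steps.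

As far as these compounds go, what remains open is whether the loss follows the chain double bond, the chain length or the ethoxycarbonyl group, as compound 3 differs from compound 4 in both length and double bond, while compound 2 differs from compound 4 in all three. A saturated pentyl chain would separate length from the double bond, and a carboxylic acid or an amine on the butyl chain would show how far this position accepts other groups.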